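Swapping an Aryl Group for an Ester on the Chain Carbon

The source may hold more compounds than are shown below. What is called first, only, known or untested is meant among the compounds shown, and "the series" means these compounds.

Measured compounds:
compound 1 `Nc1nc(O)c2c(n1)n(C1OC(CO)[C@@H](O)[C@H]1O)c(=O)n2CC(O)CO` gives 45 uM
compound 2 `Nc1nc(O)c2c(n1)n(C1OC(CO)[C@@H](O)[C@H]1O)c(=O)n2CC(O)CSc1ccccc1` gives 142 uM
compound 3 `COc1ccc(Cn2c(=O)n(C3OC(CO)[C@@H](O)[C@H]3O)c3nc(N)nc(O)c32)cc1` gives 135 uM

In a functional assay (B cells) with Mus musculus as the target (a higher number here means that more compound is needed for the effect, a lower number that less compound is needed), compound 3 stands second highest of the three numbers, with compound 2 nearest (a 1.1-fold lower number from compound 2 to compound 3 (0.02 log units; within the scatter)) and compound 1 furthest (a 3.0-fold higher number from compound 1 to compound 3 (0.48 log units; beyond the scatter)). Compound 4 `CCOC(=O)Cn1c(=O)n(C2OC(CO)[C@@H](O)[C@H]2O)c2nc(N)nc(O)c21` has not been measured in this assay. It differs from compound 3 in one place: ethoxycarbonyl in place of 4-methoxyphenyl on a saturated chain carbon bound to an aromatic nitrogen. Within the data shown here, the steps that bear on this change are those leading into compound 3. Exchanging the small 1,2-dihydroxyethyl group of compound 1 for the 4-methoxyphenyl group gave a 3.0-fold higher number from compound 1 to compound 3 (0.48 log units; beyond the scatter), whereas exchanging the larger 1-hydroxy-2-(phenylsulfanyl)ethyl group of compound 2 for the same aryl group gave a 1.1-fold lower number from compound 2 to compound 3 (0.02 log units; within the scatter). Removing the aryl group again in favour of the small ethoxycarbonyl group is therefore expected to move the number back toward that of compound 1, a modest step downward. Compound 4 is expected to show a 1.9-fold lower number from compound 3 to compound 4 (0.29 log units; within the scatter). The estimated value for compound 4 in this assay is 70 uM, within a range of 25 uM to 250 uM.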

Compound 4, concentration for half-maximal effect: 48 uM
Compound 4: the middle estimate sits 1.5-fold (0.16 log units) above what was measured; low and high end bracket the measured number.
By their numbers in this assay, from the lowest: compounds 1 and 4 (each within the scatter of the next); then compounds 3 and 2 (each within the scatter of the next).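

In this assay, the ethoxycarbonyl group on a saturated chain carbon bound to an aromatic nitrogen gives a 2.8-fold lower number from compound 3 to compound 4 (0.45 log units; beyond the scatter) and a 3.0-fold lower number from compound 2 to compound 4 (0.47 log units; beyond the scatter), so the higher numbers of the two compounds carrying a six-membered aromatic ring in this group are not retained by the ester. With a 1.1-fold higher number from compound 1 to compound 4 (0.03 log units; within the scatter), the ester and the 1,2-dihydroxyethyl group cannot be told apart here, which shows that the hydroxy groups of compound 1 are not required for the lower number. Nothing shown gives a reason for these differences.

The compounds leave open whether the ester itself matters or only the loss of the aromatic ring, which a carboxylic acid, a primary amide or a plain propyl chain at this place would help to separate. An unsubstituted benzyl group would likewise show what part the methoxy group plays in compound 3.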